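The source may report more compounds than this note shows. Statements on the series, on what has been measured and on what is new or still open speak of the compounds shown alone.

Working notes on the series.

Of the compounds shown here, two have numbers so far. Compound 1 `COC(CN(c1ccccc1CO)S(=O)(=O)c1ccc([N+](=O)[O-])cc1)n1cnc2c(Cl)ncnc21` gives 18700 nM in a functional assay on MCF7 cells (Homo sapiens) for antiproliferative activity; on this read-out higher numbers stand for weaker inhibition and lower numbers for stronger inhibition. Compound 2 `O=[N+]([O-])c1ccc(S(=O)(=O)N2CC(n3cnc4ncnc(Cl)c43)OCc3ccccc32)cc1` gives 1220 nM in this assay and stands lowest of the two, with compound 1 as the nearest neighbour at a markedly higher number, beyond the scatter. Within the data shown here, no pair differing in one place has been measured, so no step size is known.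

Compound 3 `O=[N+]([O-])c1ccc(S(=O)(=O)N2CC(n3cnc4c(Cl)ncnc43)OCc3ccccc32)cc1` is the next entry. It is built from the same atoms as compound 2, joined differently: a group of 10 heavy atoms (5 carbon, 4 nitrogen, 1 chlorine; one five-membered aromatic ring with 2 hetero atoms, one six-membered aromatic ring with 2 hetero atoms) in place of a group of 10 heavy atoms (5 carbon, 4 nitrogen, 1 chlorine; one five-membered aromatic ring with 2 hetero atoms, one six-membered aromatic ring with 2 hetero atoms), on a saturated ring carbon. Among the measured compounds shown here, with no measured step of this kind to lean on, the expected change is modest, and its direction cannot be called from the data. The step from compound 2 to compound 3 is therefore expected to be a 1.6-fold higher number from compound 2 to compound 3 (0.21 log units; within the scatter), around the scatter. Compound 3 is estimated at 2000 nM in this assay, within a range of 500 nM to 8000 nM.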

Compound 3, half-maximal inhibitory concentration: 2730 nM
Beside the measured number, compound 3's estimate is 1.4-fold (0.14 log units) below it, and the stated range covers the measured number.
By their numbers in this assay, from the lowest: compound 2; then compound 3; then compound 1.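

Among these compounds, this is the first measured step at this position, a saturated ring carbon of the seven-membered ring next to the ring oxygen. In this assay the exchange gives a 2.2-fold higher number from compound 2 to compound 3 (0.35 log units; beyond the scatter), a modest change but one beyond the scatter. The two groups have the same atoms and the same counted hydrogen-bond donors and acceptors, so the read-out at this position depends on more than the atoms present and their counts, and the arrangement in compound 2 gives the lower number. Nothing available explains this difference.

As far as these compounds go, it remains open whether the step keeps its size and direction when an amine or a methoxy group replaces the chlorine in both groups. From the compounds shown here alone, it is equally open whether it holds when an amine replaces the nitro group on the shared core.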